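The source may hold more compounds than are shown below. What is called first, only, known or untested is meant among the compounds shown, and "the series" means these compounds.

Values from a functional assay on HeLa cells (Homo sapiens) for cytotoxicity (on this read-out higher numbers stand for weaker inhibition of growth and lower numbers for stronger inhibition of growth), follow
Compound 1 `COc1ccc(NS(=O)(=O)c2cc(F)c(F)c(F)c2F)cc1`: 370 nM
Compound 2 `COc1ccc(NS(=O)(=O)c2cc(F)c(Cl)c(F)c2F)cc1`: 21000 nM

Compound 1 has the lower of the two numbers, so it inhibits growth more strongly. Compound 3 `COc1ccc(NS(=O)(=O)c2cc(F)c(F)c(F)c2)cc1` has not been measured yet. It differs from compound 1 by hydrogen in place of fluoro on an aromatic carbon and so carries hydrogen in place of fluoro on an aromatic carbon. Among the compounds with values here, only one measured step bears on this, and it is large: a 57-fold higher number from compound 1 to compound 2 (1.75 log units; beyond the scatter) on swapping a fluoro for chloro. That swap brings in chloro, not hydrogen, so it is only a loose guide. Going by a 57-fold higher number from compound 1 to compound 2 (1.75 log units; beyond the scatter) as that guide, a sizeable move to a higher number in this assay is expected. The expected change is an 11-fold higher number from compound 1 to compound 3 (1.03 log units; beyond the scatter) in size. The estimated value for compound 3 is 4000 nM (range 800 nM to 25000 nM).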

Compound 3, concentration for 50% growth inhibition: 3900 nM
Beside the measured number, compound 3's estimate is 1.0-fold (0.01 log units) above it, and the stated range covers the measured number.
By their numbers in this assay, from the lowest: compound 1; then compound 3; then compound 2.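

Removing the fluoro ortho to a large group and leaving only hydrogen weakens growth inhibition in this assay, with an 11-fold higher number from compound 1 to compound 3 (1.02 log units; beyond the scatter). A change at this ring carbon therefore matters too, not only the carbon changed in compound 2, and the loss occurs even though no larger atom enters. No measurement shown explains why this fluoro counts. On these data alone, whether a methyl group or an amine on this same carbon would restore the strength of compound 1 stays open. So does the effect of removing each remaining fluoro.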